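The compounds below may be only part of what the source reports. "The series", "measured", "known", "first", "only" and "open" are said of these compounds alone.

Compound 1 `CC(C)(C)[C@H](N)CN(C(=O)[C@@H]1C[C@H]1c1ccccc1)c1ccc(-c2ccccc2)cc1` and compound 2 `O=C([C@@H]1C[C@H]1c1ccccc1)N(CC1CCCNC1)c1ccc(-c2ccccc2)cc1` differ only on the saturated chain carbon bound to the amide-type nitrogen. In a functional assay for agonist activity at G protein-coupled receptor 88 (Homo sapiens), read by HTRF and cAMP accumulation (a higher number here means that more compound is needed for the effect, a lower number that less compound is needed), compound 1 gives 11 nM, and compound 2 gives 10 nM; the step of a 1.1-fold lower number from compound 1 to compound 2 (0.04 log units; within the scatter) shows that this exchange leaves the read-out where it was. Among the compounds with values here, compound 3 `CC[C@H](C)[C@H](N)CN(C(=O)[C@@H]1C[C@H]1c1ccc(OC)cc1)c1ccc(-c2ccccc2)cc1` departs from both in more than one place, on that chain and on the three-membered non-aromatic ring of carbon only, so no single measured step links it to either. For compound 3 in this assay only a limit was recorded, > 25000 nM. Within the data shown here, compound 3 is thus the one compound at the limit of > 25000 nM in this assay, at which 1 of the 3 values shown sits, and its starting point is not a number. Compound 4 `CC[C@H](C)[C@H](N)CN(C(=O)[C@@H]1C[C@H]1c1cccc(C#N)c1)c1ccc(-c2ccccc2)cc1` is derived from compound 3 by the change (3-cyanophenyl in place of 4-methoxyphenyl on a saturated ring carbon). Among the measured compounds shown here, no measured step touches this ring: the only known step concerns the chain, and it was a 1.1-fold lower number from compound 1 to compound 2 (0.04 log units; within the scatter). Because compound 3 stands at the limit of > 25000 nM in this assay, at which 1 of the 3 values shown sits, the direction of any move from it can only be toward or within the limit. For the measured compounds named here, compound 4 is therefore estimated, loosely, at 8000 nM, within a range of 300 nM to 25000 nM, with the estimated step of an at least 3.1-fold lower number from compound 3 to compound 4 (0.49 log units; beyond the scatter) resting on no measured precedent.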

Compound 4, half-maximal effective concentration: 1600 nM
For compound 4 the middle estimate is 5.0-fold (0.70 log units) above the measured one; the range from low to high includes it.
By their numbers in this assay, from the lowest: compounds 2 and 1 (each within the scatter of the next); then compound 4. At a limit, above all of these: compound 3.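

In this assay, putting 3-cyanophenyl in place of 4-methoxyphenyl on a saturated ring carbon of the three-membered ring gives an at least 15-fold lower number from compound 3 to compound 4 (1.19 log units; beyond the scatter). Within the data shown here, this is the first measured step at this position, as the earlier step concerned only the chain, where the read-out stayed within the scatter. It shows that, with the chain held the same, the aryl group on this ring carbon can move the read-out well beyond the scatter, even though the groups that leave and enter have the same count of heavy atoms and of hydrogen-bond acceptors, and compound 3 stands at a limit rather than a number, so the full size of the step stays unknown: the limit of > 25000 nM in this assay, at which 1 of the 4 values shown sits.

The compounds shown do not separate the part played by the nitrile from the part played by the loss of the methoxy group, and they do not tell how a trifluoromethyl group or an amine would read on the same aryl ring. Also open, on these data alone, is how the plain phenyl of compound 1 and compound 2 would read on the chain of compound 3 and compound 4, a link that would tie this step to their values.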